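Methoxy to hydroxy: what to expect for compound 4

A few compounds are considered here, and "the series" means these few. Any claim that something is new, unique, unknown or untested is made for them only; others in the source may bear on it.

Three compounds share one core and differ in the aromatic ring at one end. In a functional assay on LOX IMVI cells (Homo sapiens) for cytotoxicity (a higher number here means a weaker inhibitor of growth, a lower number a stronger inhibitor of growth), compound 1 `OCCCCC#Cc1ccccc1C#Cc1ccccn1` gives 27700 nM, and compound 2 `OCCCCC#Cc1ccccc1C#Cc1cccs1` gives 13900 nM. Compound 3 `COc1cccc(C#Cc2ccccc2C#CCCCCO)c1` gives 6300 nM, the lowest of the three numbers, and its gap to each of the other two lies beyond the usual scatter of repeated measurements.

The next compound, compound 4 `OCCCCC#Cc1ccccc1C#Cc1cccc(O)c1`, has hydrogen in place of methyl on an oxygen on an aromatic ring, so methoxy becomes hydroxy (hydrogen in place of methyl on an oxygen on an aromatic ring). Among the measured compounds shown here, no measured pair tests this change directly. For the measured compounds named here, the only measured step that changes a single place, a 2.0-fold lower number from compound 1 to compound 2 (0.30 log units; within the scatter), puts thiophen-2-yl in place of pyridin-2-yl on a triple-bonded carbon. It stays within the scatter, but it is a different change, so it offers only weak guidance.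

Going by these compounds, with so little to go on, no step beyond the scatter is expected in this assay, and the direction stays open. The expected result is a 1.2-fold higher number from compound 3 to compound 4 (0.08 log units; within the scatter), a step that is only an estimate. For compound 4 the estimated value is 7500 nM, with an expected range from 3000 nM to 19000 nM.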

Compound 4, concentration for 50% growth inhibition: 16700 nM
For compound 4 the middle estimate is 2.2-fold (0.35 log units) below the measured one, and the stated range covers the measured number.
By their numbers in this assay, from the lowest: compound 3; then compounds 2, 4 and 1 (each within the scatter of the next).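

In this assay, among the compounds shown here, this is the first measured change at this position that touches a single group, and taking the methyl off the oxygen gives a modest step beyond the scatter (a 2.7-fold higher number from compound 3 to compound 4 (0.42 log units; beyond the scatter)). The hydroxy compound also loses the separation that compound 3 had from the other two compounds, since both of its remaining steps stay within the scatter (a 1.2-fold higher number from compound 2 to compound 4 (0.08 log units; within the scatter); a 1.7-fold lower number from compound 1 to compound 4 (0.22 log units; within the scatter)), so the lead of compound 3 in this small set depends on that methyl and not merely on having a substituted phenyl ring at this end. Nothing available here gives a measured reason for this step.

The compounds shown carry only methoxy and hydroxy at this place, so it stays open whether a larger ether such as ethoxy would lower the number further, and whether an amine or a fluorine there would behave like either of them. Going by these compounds, it is also open whether the same methoxy to hydroxy change gives a similar step when the chain at the other end of the core is a longer chain or ends in a carboxylic acid.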